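Losing the aromatic methyl from compound 3

This account rests on a few compounds, and the source may have more. Where it says the series, first, only, none or still open, it means among the compounds named here.

In a functional assay for inhibition, with Homo sapiens as the target (a higher number here means a weaker inhibitor, a lower number a stronger inhibitor), compound 1 `Cc1cc2c(cc1C(=O)N=C(N)N)S(=O)(=O)CC2C` gives 182 nM, compound 2 `Cc1cc2c(cc1C(=O)N=C(N)N)S(=O)(=O)CC2N` gives 692 nM, and compound 3 `COC1CS(=O)(=O)c2cc(C(=O)N=C(N)N)c(C)cc21` gives 208 nM. Compound 3 stands level with compound 1, with a 1.1-fold higher number from compound 1 to compound 3 (0.06 log units; within the scatter), and the measured gap on its other side is a 3.3-fold lower number from compound 2 to compound 3 (0.52 log units; beyond the scatter).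

Compound 4 `COC1CS(=O)(=O)c2cc(C(=O)N=C(N)N)ccc21` carries a different change: hydrogen in place of methyl on an aromatic carbon. This is hydrogen in place of methyl on an aromatic carbon, ortho to a group of 6 heavy atoms. Among the compounds with values here, no measured step touches that carbon. The nearest guide is the set of changes on a saturated ring carbon, which span a 1.1-fold higher number from compound 1 to compound 3 (0.06 log units; within the scatter) and a 3.8-fold higher number from compound 1 to compound 2 (0.58 log units; beyond the scatter), so a modest step is a reasonable size to expect. These compounds do not show the direction, and a higher number is only a tentative expectation.

The expected change is a 2.9-fold higher number from compound 3 to compound 4 (0.46 log units; beyond the scatter). For compound 4 the estimated value is 600 nM, with an expected range of 170 nM to 2200 nM.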

Compound 4, half-maximal inhibitory concentration: > 100000 nM
Compound 4: only a limit was reported; the forecaster's own chance of this, stated with the estimate: 5%; middle value at least 160-fold (2.22 log units) away from the limit.
By their numbers in this assay, from the lowest: compounds 1 and 3 (each within the scatter of the next); then compound 2. At a limit, above all of these: compound 4.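

In this assay, the methyl on the aromatic carbon, ortho to a group of 6 heavy atoms, matters far more than any group compared on the saturated ring carbon: removing it gives an at least 480-fold higher number from compound 3 to compound 4 (2.68 log units; beyond the scatter), whereas the largest earlier step is a 3.8-fold higher number from compound 1 to compound 2 (0.58 log units; beyond the scatter). Compound 4 is reported only as a limit: the limit of > 100000 nM in this assay, at which 1 of the 4 values shown sits. All three compounds that keep the methyl give measurable numbers, with methyl, amino or methoxy on the saturated ring carbon, so in this small set the loss of one carbon at this position outweighs those changes.

The compounds shown leave open whether the methyl itself is needed or whether another group on that carbon, such as ethyl or chlorine, would serve as well. They also leave open whether hydrogen at this carbon would have the same outcome with amino or methyl on the saturated ring carbon.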